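Swapping hydroxymethyl for 1-hydroxycyclohexyl on a shared core

A few compounds are considered here, and "the series" means these few. Any claim that something is new, unique, unknown or untested is made for them only; others in the source may bear on it.

In a functional assay on MiaPaCa cells (Homo sapiens) for antiproliferative activity, read by sulforhodamine B assay, with a stated time of 48 h (on this read-out higher numbers stand for weaker inhibition of growth and lower numbers for stronger inhibition of growth), two compounds on one core have been measured so far. Compound 1 `O=C1COc2ccccc2N1CCCn1cc(-c2ccccn2)nn1` with pyridin-2-yl gives 5800 nM and compound 2 `O=C1COc2ccccc2N1CCCn1cc(CO)nn1` with hydroxymethyl gives 1010 nM as the lower of the two numbers, so compound 2 stands as the stronger inhibitor of growth. Compound 3 `O=C1COc2ccccc2N1CCCn1cc(C2(O)CCCCC2)nn1` carries 1-hydroxycyclohexyl in place of hydroxymethyl on an aromatic carbon, a change counted as 1-hydroxycyclohexyl in place of hydroxymethyl on an aromatic carbon and still unmeasured. Among the compounds with values here, the one measured step bearing on it is a 5.7-fold lower number from compound 1 to compound 2 (0.76 log units; beyond the scatter) and is modest yet beyond the scatter. That step concerns the same place on the core, and there the larger, ring-bearing group stood on the higher number. A single step is thin evidence, and 1-hydroxycyclohexyl differs from pyridin-2-yl in not being aromatic, so only a modest rise is expected in this assay with wide uncertainty. The expected step is a 2.2-fold higher number from compound 2 to compound 3 (0.34 log units; beyond the scatter) and is smaller than the measured one. In this assay compound 3 is expected at 2200 nM with a range from 500 nM to 8000 nM as the estimate.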

Compound 3, concentration for 50% growth inhibition: 2500 nM
Compound 3: the middle estimate sits 1.1-fold (0.06 log units) below what was measured; low and high end bracket the measured number.
By their numbers in this assay, from the lowest: compound 2; then compound 3; then compound 1.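

In this assay, the change to 1-hydroxycyclohexyl brings a 2.5-fold higher number from compound 2 to compound 3 (0.39 log units; beyond the scatter) even though the entering and leaving groups have equal counts of hydrogen-bond donors and acceptors, so at this place the added six-membered non-aromatic ring of carbon goes with weaker inhibition of growth. Set against pyridin-2-yl, the same group gives a 2.3-fold lower number from compound 1 to compound 3 (0.37 log units; beyond the scatter) and so shows that the two ring-bearing groups do not sit on one level: the non-aromatic ring stands on the lower number, while hydroxymethyl, with no ring, still stands lowest of the three. The compounds give no measurement that could explain either difference.

From the compounds shown here alone, what stays open is how much of the result belongs to the hydroxyl of 1-hydroxycyclohexyl and how much to its ring, a question that plain cyclohexyl at this place would address. Within the data shown here, with only two hydroxyl-bearing groups in view, it is also open how a longer chain such as 2-hydroxyethyl, or an amine such as aminomethyl, would stand against hydroxymethyl on this aromatic carbon.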